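Taking One Methoxy Group from Compound 2

The source may hold more compounds than are shown below. What is called first, only, known or untested is meant among the compounds shown, and "the series" means these compounds.

In a functional assay on NCI/ADR-RES cells (Homo sapiens) for inhibition, read by sulforhodamine B assay, with a stated time of 48 h (a lower number here means a stronger inhibitor of growth, a higher number a weaker inhibitor of growth), compound 1 `COc1ccc(/C=C/C2(C)C=CC(=O)O2)c(OC)c1` gives 151000 nM and compound 2 `COc1ccc(/C=C/C2(C)C=CC(=O)O2)cc1OC` gives 111000 nM. These two numbers lie within the scatter of each other, so compound 2 stands level with compound 1. Compound 3 `COc1ccc(/C=C/C2(C)C=CC(=O)O2)cc1` follows from compound 2 with hydrogen in place of methoxy on an aromatic carbon, ortho to a methoxy group and meta to a group of 9 heavy atoms (hydrogen in place of methoxy on an aromatic carbon). Within the data shown here, no measured step between compounds in this set shows what such a change does in this assay. Among the measured compounds shown here, the only guide is that compound 2, at 111000 nM, sits within the scatter of its sole neighbour. The estimated 1.2-fold higher number from compound 2 to compound 3 (0.07 log units; within the scatter) is therefore expected to stay within the scatter, with no clear shift in either direction. Compound 3 is expected at 130000 nM, within an estimated range of 70000 nM to 240000 nM.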

Compound 3, concentration for total growth inhibition: > 1000000 nM
Compound 3 ended at the assay's limit (the forecaster's own chance of this, stated with the estimate: 15%); middle value at least 7.6-fold (0.88 log units) away from the limit.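

Hydrogen in place of methoxy gives an at least 9.0-fold higher number from compound 2 to compound 3 (0.95 log units; beyond the scatter), and the same exchange gives an at least 6.6-fold higher number from compound 1 to compound 3 (0.82 log units; beyond the scatter). Among these compounds, compound 1 and compound 2, which each carry two methoxy groups, stand level, so where the second methoxy group sits made no clear difference among the earlier compounds, while compound 3, with a single methoxy group, shows that having the second group at all goes with stronger growth inhibition. The value of compound 3 is a limit of the assay and not a number, so both steps give only a lower bound on the size of the change: the limit of > 1000000 nM in this assay, at which 1 of the 3 values shown sits.

From the compounds shown here alone, how far compound 3 lies past that limit stays open. Also open, going by these compounds, is whether a hydroxyl group, a fluorine atom or an ethoxy group on the same aromatic carbon would keep the growth inhibition seen with compound 2.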